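The source may report more compounds than this note shows. Statements on the series, on what has been measured and on what is new or still open speak of the compounds shown alone.

Measured compounds:
- Compound 1, `N[C@H]1CC[C@H](Nc2c(C(=O)NCc3ccc(Cl)cc3)nc(Br)c3cccnc23)CC1`, gives 1000 nM in a functional assay on MDA-MB-435 cells (Homo sapiens) for cytotoxicity, read by MTT assay, with a stated time of 72 h; a higher number here means a weaker inhibitor, a lower number a stronger inhibitor.
- Compound 2, `N[C@H]1CC[C@H](Nc2c(C(=O)NCc3ccc(Oc4ccccc4)cc3)nc(Br)c3cccnc23)CC1`, gives 4000 nM in this assay.
- Compound 3, `COC(=O)c1nc(Br)c2cccnc2c1N[C@H]1CC[C@H](N)CC1`, reaches only the limit of this assay, > 20000 nM, which is a limit and not a number.

Compound 1 holds the lowest of the two numbers, and compound 2 is its nearest neighbour with a 4.0-fold higher number from compound 1 to compound 2 (0.60 log units; beyond the scatter). Compound 3 sits at the limit of > 20000 nM in this assay, at which 1 of the 3 values shown sits, where its change from compound 1 was an at least 20-fold higher number from compound 1 to compound 3 (1.30 log units; beyond the scatter).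

Compound 4, `N[C@H]1CC[C@H](Nc2c(C(=O)NCc3cccc(C(F)(F)F)c3)nc(Br)c3cccnc23)CC1`, differs from compound 1 in one place: 3-(trifluoromethyl)phenyl in place of 4-chlorophenyl on a saturated chain carbon bound to an amide-type nitrogen. Within the data shown here, two measured steps bear on this. Replacing chloro with phenoxy on the same aromatic ring weakened the inhibitor modestly, while removing the whole (4-chlorobenzyl)amino group in compound 3 weakened it greatly. Compound 4 keeps that benzyl group and only alters its substituent, so a step no larger than the modest one, towards a higher number or within the scatter, is expected: a 2.0-fold higher number from compound 1 to compound 4 (0.30 log units; within the scatter) is the expected step. Compound 4 is therefore estimated at 2000 nM, in the range 700 nM to 6000 nM.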

Compound 4, half-maximal inhibitory concentration: 4200 nM
The estimate for compound 4 lay 2.1-fold (0.32 log units) below the measured number; low and high end bracket the measured number.
By their numbers in this assay, from the lowest: compound 1; then compounds 2 and 4 (each within the scatter of the next). At a limit, above all of these: compound 3.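

In this assay, the change from 4-chlorobenzyl to 3-(trifluoromethyl)benzyl gives a 4.2-fold higher number from compound 1 to compound 4 (0.62 log units; beyond the scatter), so the aromatic ring on the saturated chain carbon bound to an amide-type nitrogen does not accept this replacement without loss. Together with compound 2, this makes two different replacements of the 4-chlorophenyl group that each raise the number beyond the scatter, while compound 2 and compound 4 stand within the scatter of each other, and compound 1 keeps the lowest number so far. No measurement shown here bears on what lies behind this rise.

Going by these compounds, this change alters both the substituent and its numbered place on the ring, so the effect of each alone remains open. A plain benzyl group, or a benzyl ring carrying an amine or a carboxylic acid, would show how much the chloro substituent itself contributes.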